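Series notes: removing the chloro substituent from compound 1

The source may report more compounds than this note shows. Statements on the series, on what has been measured and on what is new or still open speak of the compounds shown alone.

Measured so far in a physicochemical assay for lipophilicity; a higher number here means a more lipophilic compound, a lower number a more polar compound:
- compound 1 `CCc1nn(CCO)c(CC)c1Oc1cc(Cl)cc(C#N)c1` gives 3.3
- compound 2 `CCc1nn(CCN)c(CC)c1Oc1cc(C)cc(C#N)c1` gives 1.5
- compound 3 `CCc1nn(CCN)c(CC)c1Oc1cc(C#N)cc(C#N)c1` gives 0.9

Compound 1 holds the highest of the three numbers in this assay; the nearest is compound 2, whose number lies beyond the scatter below it, and the furthest is compound 3, further below still. These two gaps each combine more than one structural change, so no single-point step can be read from them. Among the measured compounds shown here, the only single-point step measured is a number 0.60 log units lower from compound 2 to compound 3 (beyond the scatter), which concerns a different substituent on the same six-membered ring and therefore does not cover the present change.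

Compound 4 `CCc1nn(CCO)c(CC)c1Oc1cccc(C#N)c1` differs from compound 1 by hydrogen in place of chloro on an aromatic carbon. For the measured compounds named here, no measured pair in this set removes a chloro group, so the expectation rests on the general tendency of such a change alone. Removing chloro is expected to give a modest lowering in this assay, about a number 0.70 log units lower from compound 1 to compound 4 (beyond the scatter). Compound 4 is thus estimated at 2.6, with a range from 2.1 to 3.1.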

Compound 4, distribution coefficient: 2.7
Compound 4: middle estimate off by 0.10 log units, on the low side, within the range that was stated.
By their numbers in this assay, from the lowest: compound 3; then compound 2; then compound 4; then compound 1.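

In this assay hydrogen in place of chloro now has a measured step of its own on this aromatic carbon, meta to a cyano group (a number 0.60 log units lower from compound 1 to compound 4 (beyond the scatter)). Among the compounds shown here, the earlier compounds offered only one single-point step on this carbon (a number 0.60 log units lower from compound 2 to compound 3 (beyond the scatter)), which concerned a different change and a different chain on the shared core, while the gaps from compound 1 to compound 2 and compound 3 combined more than one change. No supporting evidence is available to explain the size of the new step.

The compounds shown leave open how fluoro, methoxy or trifluoromethyl on this carbon would compare with the hydrogen of compound 4. They also leave open whether removing chloro gives a similar step when the chain on the core carries the amine of compound 2.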